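This account rests on a few compounds, and the source may have more. Where it says the series, first, only, none or still open, it means among the compounds named here.

Measured so far in a functional assay on HOS-TE85 cells (Homo sapiens) for inhibition, read by CCK-8 assay, with a stated time of 72 h; on this read-out lower numbers stand for stronger inhibition and higher numbers for weaker inhibition:
- compound 1 `O=C(NCCCCn1cccn1)c1cccc(C2SCC(=O)N2c2cc(Br)ccn2)c1`: 105 nM
- compound 2 `COc1ccccc1N1C(=O)CSC1c1cccc(C(=O)NCCCCn2cccn2)c1`: 91.7 nM
- compound 3 `O=C(NCCCCn1cccn1)c1cccc(C2SCC(=O)N2c2cccc(C3CC3)c2)c1`: 299 nM

Among these three, compound 3 gives the highest number, at 299 nM, and so the weakest inhibition. The other two stand close together, with a 1.1-fold lower number from compound 1 to compound 2 (0.06 log units; within the scatter). Compound 3 is separated from them by a 2.8-fold higher number from compound 1 to compound 3 (0.45 log units; beyond the scatter) and by a 3.3-fold higher number from compound 2 to compound 3 (0.51 log units; beyond the scatter).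

The next entry is compound 4 `O=C(NCCCCn1cccn1)c1cccc(C2SCC(=O)N2c2ccncc2)c1`, so far unmeasured. It carries pyridin-4-yl in place of 3-cyclopropylphenyl on an amide-type nitrogen in a ring.

Going by the values given here, all three measured steps concern this same place, so they are the only guide. Both steps that reach compound 3 are modest, and the change here also leaves 3-cyclopropylphenyl, so they point toward a lower number. Among the compounds with values here, compound 1, at 105 nM, is the closest comparison, as the only measured compound with a pyridine ring on this nitrogen, though its ring bears bromine. Within the data shown here, no measured compound carries pyridin-4-yl itself, so a full return to the level of compounds 1 and 2 is not assumed.

The expected change in this assay is modest and downward: a 2.0-fold lower number from compound 3 to compound 4 (0.30 log units; within the scatter). The estimated value for compound 4 is 150 nM, with an expected range from 55 nM to 400 nM.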

Compound 4, half-maximal inhibitory concentration: > 1000 nM
Compound 4 was reported as a limit; the forecaster's own chance of this, stated with the estimate: 2%; middle value at least 6.6-fold (0.82 log units) from the limit.
By their numbers in this assay, from the lowest: compounds 2 and 1 (each within the scatter of the next); then compound 3. At a limit, above all of these: compound 4.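

In this assay compound 4 stands at a limit, > 1000 nM, and not at a number. Leaving 3-cyclopropylphenyl for pyridin-4-yl on the amide-type nitrogen gives an at least 3.3-fold higher number from compound 3 to compound 4 (0.52 log units; beyond the scatter), and the two other comparisons at this place give an at least 10-fold higher number from compound 2 to compound 4 (1.03 log units; beyond the scatter) and an at least 9.5-fold higher number from compound 1 to compound 4 (0.97 log units; beyond the scatter), so this place is more sensitive than the earlier steps suggested, the largest of which was a 3.3-fold higher number from compound 2 to compound 3 (0.51 log units; beyond the scatter). A pyridine ring on this nitrogen does not by itself set the level in this assay, since compound 1, with 4-bromopyridin-2-yl, gives 105 nM.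

On these data alone, compound 1 and compound 4 differ both in where the ring nitrogen sits and in the bromine, so these notes cannot say which of the two accounts for the gap, and how far compound 4 lies past its limit also stays unknown. Open as well is how an unsubstituted phenyl, a pyridin-3-yl, or a pyridin-4-yl carrying bromine or methoxy would read at this place.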